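Moving a Chlorine Around the Benzyl Ring

The source may report more compounds than this note shows. Statements on the series, on what has been measured and on what is new or still open speak of the compounds shown alone.

Compound 1 `Cc1cc(S(=O)(=O)/N=C(\N)n2nccc2-c2ccccc2)c(SCc2cccc(Cl)c2)cc1Cl` gives a half-life of 0.309 h in an ADME assay on microsomes from liver (Homo sapiens) for metabolic stability, read by LC-MS, using NADPH, tested at 5 uM; on this read-out lower numbers stand for a shorter-lived compound and higher numbers for a longer-lived compound. Compound 2 `Cc1cc(-c2ccccc2)n(/C(N)=N/S(=O)(=O)c2cc(C)c(Cl)cc2SCc2cccc(C(F)(F)F)c2)n1` gives 0.169 h in this assay, a number within the usual scatter of compound 1, so the two cannot be told apart. Compound 3 `Cc1cc(S(=O)(=O)/N=C(\N)n2nccc2-c2ccccc2)c(SCc2ccc(Cl)cc2)cc1Cl` has not yet been measured. Compound 3 differs from compound 1 only in this way: 4-chlorophenyl in place of 3-chlorophenyl on a saturated chain carbon bound to a sulfur. Within the data shown here, with no measured step of this kind to lean on, the change is expected to leave compound 3 within the scatter of compound 1, a step of a 1.0-fold lower number from compound 1 to compound 3 (0.01 log units; within the scatter). Compound 3 is therefore estimated at 0.3 h, between 0.15 h and 0.6 h.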

Compound 3, half-life: 0.34 h
Estimate against measurement, compound 3: 1.1-fold (0.05 log units) below, within the range that was stated.
By their numbers in this assay, from the lowest: compounds 2, 1 and 3 (each within the scatter of the next).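

Swapping 3-chlorophenyl for 4-chlorophenyl on a saturated chain carbon bound to a sulfur gives the only measured step of this kind in this assay (a 1.1-fold higher number from compound 1 to compound 3 (0.04 log units; within the scatter)). At this place, then, the half-life does not tell the two chlorine placements apart, and compound 1 and compound 3 cannot be separated. Nothing measured here offers an explanation for this result.

Still open, as far as these compounds go, is whether a methoxy group or an amine in place of the chlorine would also stay within the scatter of compound 1. The same question stands for a plain phenyl carrying no chlorine at all.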